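The source may hold more compounds than are shown below. What is called first, only, known or untested is meant among the compounds shown, and "the series" means these compounds.

Compound 1 `Nc1sc(Br)c(-c2cccc(C(F)(F)F)c2)c1C(=O)c1ccccc1` is the starting point, and in a functional assay on CHO-K1 cells for agonist activity at adenosine receptor A1 (Homo sapiens), read by GTPgammaS binding (a lower number here means that less compound is needed, a higher number that more compound is needed for the effect), compound 1 gives only a limit of > 10 uM, so no number is known for it (the limit of > 10 uM in this assay, at which 1 of the 3 values shown sits). Compound 2 `Nc1scc(-c2cccc(C(F)(F)F)c2)c1C(=O)c1ccccc1` gives 15.8 uM in this assay, and compound 3 `Nc1sc(-c2ccccc2)c(-c2cccc(C(F)(F)F)c2)c1C(=O)c1ccccc1` gives 2.3 uM. The step that the limit leaves unreadable from compound 1 to compound 2 cannot be sized; the step of an at least 4.3-fold lower number from compound 1 to compound 3 (0.63 log units; beyond the scatter) is a drop, as is a 6.9-fold lower number from compound 2 to compound 3 (0.84 log units; beyond the scatter). Compound 4 `CC(=O)c1cccc(-c2sc(N)c(C(=O)c3ccccc3)c2-c2cccc(C(F)(F)F)c2)c1` differs from compound 1 by 3-acetylphenyl in place of bromo on an aromatic carbon. This resembles the phenyl replacement of compound 1 to compound 3, so a similar drop is expected, an at least 4.0-fold lower number from compound 1 to compound 4 (0.60 log units; beyond the scatter). Compound 4 is therefore estimated at 2.5 uM, with a likely range from 0.7 uM to 9 uM.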

Compound 4, concentration for half-maximal effect: > 10 uM
Compound 4 was reported as a limit; the forecaster's own chance of this, stated with the estimate: 15%; at least 4.0-fold (0.60 log units) between middle value and limit.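

In this assay, the aryl group next to the ring sulfur proves sensitive to substitution: acetyl in place of hydrogen on the phenyl of compound 3 gives an at least 4.3-fold higher number from compound 3 to compound 4 (0.63 log units; beyond the scatter). A phenyl ring at this position therefore does not carry the lower number of compound 3 regardless of what it bears. The value of compound 4 is a limit: the limit of > 10 uM in this assay, at which 2 of the 4 values shown sit. The steps to compound 4 from compound 1 and compound 2 cannot be read.

From the compounds shown here alone, it remains open whether an amine or a carboxylic acid in place of acetyl would keep the number of compound 3.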